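The compounds below may be only part of what the source reports. "The series", "measured", "known", "first", "only" and "open" are said of these compounds alone.

Measured in a functional assay on SK-BR-3 cells (Homo sapiens) for antiproliferative activity, read by MTT assay, with a stated time of 72 h; on this read-out lower numbers stand for stronger inhibition and higher numbers for weaker inhibition:
- Compound 1 `CCN1CCN(c2cc(C)c3cc(NC(=O)c4cccnc4)ccc3n2)CC1`: 10600 nM
- Compound 2 `CCc1ccccc1C(=O)Nc1ccc2nc(N3CCN(CC)CC3)cc(C)c2c1`: 23900 nM
- Compound 3 `CCN1CCN(c2cc(C)c3cc(NC(=O)c4ccccc4OC)ccc3n2)CC1`: 15700 nM

Compound 3 cannot be separated from either of the other two compounds on these numbers. The data show a 1.5-fold higher number from compound 1 to compound 3 (0.17 log units; within the scatter) and a 1.5-fold lower number from compound 2 to compound 3 (0.18 log units; within the scatter). Within the data shown here, only one measured step clears the scatter, and modestly so: a 2.3-fold higher number from compound 1 to compound 2 (0.35 log units; beyond the scatter).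

The unmeasured compound 4 `CCN1CCN(c2cc(C)c3cc(NC(=O)c4ccc(OC)cc4)ccc3n2)CC1` keeps the shared core and the amide of compound 3 and differs only in where the methoxy group sits: 4-methoxyphenyl in place of 2-methoxyphenyl on a carbonyl carbon. In short, it has 4-methoxyphenyl in place of 2-methoxyphenyl on a carbonyl carbon.

Among the measured compounds shown here, no measured pair shows this exact change, so the evidence is indirect. The three measured steps all concern the group on that same carbonyl carbon, and even the replacement of one group by a different one moved the number only slightly. No step beyond the scatter is therefore expected in this assay, and these data give no direction for one.

The estimate stays close to compound 3 at 15700 nM, and it means a 1.0-fold lower number from compound 3 to compound 4 (0.02 log units; within the scatter), an expected change within the scatter. Compound 4 is estimated at 15000 nM. The expected range for this estimate runs from 6500 nM to 35000 nM.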

Compound 4, half-maximal inhibitory concentration: 9000 nM
Compound 4: middle estimate off by 1.7-fold (0.22 log units), on the high side; measured number inside the range.
By their numbers in this assay, from the lowest: compounds 4, 1, 3 and 2 (each within the scatter of the next, the first and the last beyond it).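

Among these compounds, changing 2-methoxyphenyl to 4-methoxyphenyl on a carbonyl carbon is the only step here that rearranges the same atoms rather than replacing one group with a different one. In this assay it gives a 1.7-fold lower number from compound 3 to compound 4 (0.24 log units; within the scatter), so the two placements of the methoxy group cannot be separated on these numbers, and neither can 4-methoxyphenyl and pyridin-3-yl, at a 1.2-fold lower number from compound 1 to compound 4 (0.07 log units; within the scatter). Among the compounds shown here, the one new step that clears the scatter is modest, at a 2.7-fold lower number from compound 2 to compound 4 (0.42 log units; beyond the scatter); with the earlier step from compound 1 to compound 2, it sets the 2-ethylphenyl amide of compound 2 apart from two of the other amides, though not from compound 3, and no measurement offered here accounts for any of these differences.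

Still open, from the compounds shown here alone, is whether 3-methoxyphenyl, or a phenyl group carrying an amine or a carboxylic acid, on the same carbonyl carbon would clear the scatter against compound 4. Also open, going by these compounds, is whether a change to the shared core, which all four compounds keep, would move the number further than any group on the carbonyl carbon has.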